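Second methoxycarbonyl extended to propoxycarbonyl: working notes

The source may hold more compounds than are shown below. What is called first, only, known or untested is meant among the compounds shown, and "the series" means these compounds.

Measured compounds:
compound 1, `CCc1nc(Cl)c(C2C(C(=O)OC)=C(C)NC(C)=C2C(=O)OC)[nH]1`, gives 0.596 nM
compound 2, `CCCOC(=O)C1=C(C)NC(C)=C(C(=O)OC)C1c1[nH]c(CC)nc1Cl`, gives 0.146 nM

Both values come from an assay on ileum for inhibition of Voltage-dependent L-type calcium channel subunit alpha-1C (Cavia porcellus); on this read-out lower numbers stand for stronger inhibition and higher numbers for weaker inhibition. Going by the values given here, compound 2 stands at the lower of the two numbers; its only comparator is compound 1, and the single measured step is a 4.1-fold lower number from compound 1 to compound 2 (0.61 log units; beyond the scatter), an ethyl in place of hydrogen on a saturated chain carbon bound to an oxygen next to a carbonyl group, which reads as methoxycarbonyl to propoxycarbonyl.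

Compound 3, `CCCOC(=O)C1=C(C)NC(C)=C(C(=O)OCCC)C1c1[nH]c(CC)nc1Cl`, is not yet measured in this assay. It differs from compound 2 by ethyl in place of hydrogen on a saturated chain carbon bound to an oxygen next to a carbonyl group, so the remaining methoxycarbonyl is extended to propoxycarbonyl. The only step that bears on this is a 4.1-fold lower number from compound 1 to compound 2 (0.61 log units; beyond the scatter), the same change applied to the other ester; whether a second such extension repeats it is not shown by the two numbers available. The expected step is a 1.8-fold lower number from compound 2 to compound 3 (0.26 log units; within the scatter), a further decrease smaller than the measured step. Compound 3 is therefore estimated at 0.08 nM, with a range from 0.03 nM to 0.25 nM.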

Compound 3, half-maximal inhibitory concentration: 0.13 nM
Estimate against measurement, compound 3: 1.6-fold (0.21 log units) below; measured number inside the range.
By their numbers in this assay, from the lowest: compounds 3 and 2 (each within the scatter of the next); then compound 1.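

In this assay, extending the remaining methoxycarbonyl to propoxycarbonyl gives a 1.1-fold lower number from compound 2 to compound 3 (0.05 log units; within the scatter), so compound 2 and compound 3 cannot be told apart on this read-out. The same change on the other ester gave a 4.1-fold lower number from compound 1 to compound 2 (0.61 log units; beyond the scatter), which means that across these three compounds the change has no fixed size: it is beyond the scatter when it replaces the methoxycarbonyl of compound 1 and within the scatter when it replaces the methoxycarbonyl of compound 2, where a propoxycarbonyl is already present. Nothing available here accounts for the difference between the two steps.

Still open, from the compounds shown here alone, is whether a longer chain, as in butoxycarbonyl or pentyloxycarbonyl, on either ester would separate from compound 3 beyond the scatter, or whether the numbers stay level as the chain grows. Also open is how far the number would move if either propoxycarbonyl of compound 3 were replaced by a carboxylic acid or a primary amide, since all three compounds shown carry only simple chain esters at these two places.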